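The compounds below may be only part of what the source reports. "The series", "measured", "known", "first", "only" and "open" are said of these compounds alone.

Measured so far in a functional assay on DU-145 cells (Homo sapiens) for inhibition, read by trypan blue exclusion, with a stated time of 96 h; on this read-out lower numbers stand for stronger inhibition of growth and higher numbers for weaker inhibition of growth:
- compound 1 `COc1cc(/C=C(/SCc2ccc(Br)cc2)C(=O)c2ccc(C(=O)O)cc2)ccc1F`: 1000 nM
- compound 2 `O=C(O)c1ccc(C(=O)/C(=C\c2ccc(Br)c([N+](=O)[O-])c2)SCc2ccc(Cl)cc2Cl)cc1`: 1000 nM
- compound 3 `CSc1ccc(/C=C(/SCc2ccc(Br)cc2)C(=O)c2ccc(C(=O)O)cc2)cc1`: 10000 nM

Compound 3 has the highest number of the three, so it is the weakest growth inhibitor here, and its gaps to compound 1 and compound 2 both lie beyond the scatter. The next compound, compound 4 `O=C(O)c1ccc(C(=O)/C(=C\c2ccc(Br)c([N+](=O)[O-])c2)SCc2ccc(Br)cc2)cc1`, keeps the rest of compound 3 and changes one group: 4-bromo-3-nitrophenyl replaces 4-(methylsulfanyl)phenyl on a double-bonded chain carbon bound to a double-bonded chain carbon, (4-bromo-3-nitrophenyl in place of 4-(methylsulfanyl)phenyl on a double-bonded chain carbon bound to a double-bonded chain carbon).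

Within the data shown here, one measured step bears directly on this place. Putting 4-(methylsulfanyl)phenyl there in place of 4-fluoro-3-methoxyphenyl gave a 10-fold higher number from compound 1 to compound 3 (1.00 log units; beyond the scatter), a clear move beyond the scatter. A second clue is that compound 2 already carries 4-bromo-3-nitrophenyl and gives 1000 nM, although its remaining structure is not identical to that of compound 4. With so few compounds this is only a rough guide, but a lower number is expected once the group of compound 3 is gone.

The expected change is a 10-fold lower number from compound 3 to compound 4 (1.00 log units; beyond the scatter), similar in size to the measured step. For compound 4 the estimated value is 1000 nM, with an expected range from 300 nM to 4000 nM.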

Compound 4, concentration for 50% growth inhibition: 1000 nM
Estimate against measurement, compound 4: no gap at the digits printed, within the range that was stated.
By their numbers in this assay, from the lowest: compounds 1, 2 and 4 (each within the scatter of the next); then compound 3.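

In this assay, 4-bromo-3-nitrophenyl on a double-bonded chain carbon bound to a double-bonded chain carbon gave a 10-fold lower number from compound 3 to compound 4 (1.00 log units; beyond the scatter), so a second group now shows that the number seen with 4-(methylsulfanyl)phenyl is not fixed by the rest of the structure. 4-Bromo-3-nitrophenyl and 4-fluoro-3-methoxyphenyl cannot be told apart at this place, with no change at the digits printed from compound 1 to compound 4 (within the scatter), and the other end of the molecule also showed no shift, since 4-bromophenyl in place of 2,4-dichlorophenyl on a saturated chain carbon bound to a sulfur gave no change at the digits printed from compound 2 to compound 4 (within the scatter). No measurement at hand explains why these groups give these numbers.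

The compounds shown leave open whether 4-(methylsulfanyl)phenyl stands alone with its higher number or whether other groups at this place, such as an unsubstituted phenyl or a phenyl carrying an amine, would join it. They also leave open whether the carboxylic acid, present in every compound shown, could give way to an amide without changing the number.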